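The compounds below may be only part of what the source reports. "The series", "measured", "known", "first", "only" and "open" are said of these compounds alone.

Within the data shown here, in an ADME assay (liver) for metabolic stability, with Liver microsome (Rattus norvegicus) as the target, read by LC-MS, using microsomes and NADPH, with stated times of 5 min and 60 min, tested at 4 uM (on this read-out lower numbers stand for a less stable compound and higher numbers for a more stable compound), compound 1 `Cc1cc(C(=O)O)ccc1OCCCCOc1ccc(C(=O)CC(C)C)c(O)c1C` gives 41% as the higher of the two numbers so far. Compound 2 `Cc1c(OCCCCOc2cccc(C(=O)O)c2)ccc(C(=O)CC(C)C)c1C` gives 29% and sits lower by a gap beyond the usual scatter of repeat measurements. These two compounds differ in more than one place, so their gap cannot be pinned on any single group.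

Compound 3 `Cc1c(OCCCCOc2ccc(C(=O)O)cc2Cl)ccc(C(=O)CC(C)C)c1O` has not yet been measured. It departs from compound 1 in one spot (chloro in place of methyl on an aromatic carbon), with chloro in place of methyl on an aromatic carbon, ortho to a large group and meta to a carboxy group. Among the measured compounds shown here, no measured pair shows this exchange, so the expectation rests on compound 1 at 41% and allows only a small rise that stays within the scatter. The expected step of a number 5 percentage points higher from compound 1 to compound 3 (within the scatter) is therefore modest. In this assay compound 3 is estimated at 46% (range 30% to 62%).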

Compound 3, percent of the compound remaining: 61%
Compound 3: middle estimate off by 15 percentage points, on the low side, within the range that was stated.
By their numbers in this assay, from the lowest: compound 2; then compound 1; then compound 3.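

Chloro in place of methyl on an aromatic carbon, which turns the 4-carboxy-2-methylphenyl end into 4-carboxy-2-chlorophenyl, is the first change in this series that can be read on its own, and in this assay it gives a number 20 percentage points higher from compound 1 to compound 3 (beyond the scatter) with the rest of the structure unchanged. This shows that the position, ortho to a large group and meta to a carboxy group, is not indifferent in this read-out: exchanging a single small group here is enough to move the number past the usual scatter. Nothing measured here says why the exchange has this effect.

As far as these compounds go, whether fluoro, bromo, methoxy or a nitrile at this same place would follow chloro remains open. So does whether chloro would give a similar step on the other ring of the core or on the framework of compound 2.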